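The source may hold more compounds than are shown below. What is called first, only, known or untested is meant among the compounds shown, and "the series" means these compounds.

In a functional assay on PC-3 cells (Homo sapiens) for cytotoxicity, read by WST assay, with a stated time of 72 h (a higher number here means a weaker inhibitor, a lower number a stronger inhibitor), compound 1 `O=C1Nc2c(ccc(F)c2F)C1(c1ccc(O)cc1)c1cccs1` gives 0.3 nM. Compound 3 `Cc1c(Cl)ccc2c1NC(=O)C2(c1ccc(O)cc1)C1CCCCCC1` gives 150 nM, the higher of the two exact numbers here, and its gap to compound 1 lies well beyond the scatter. For compound 2 `Cc1cc(F)cc2c1NC(=O)C2(c1ccc(O)cc1)C1CCCCCC1`, the result of > 1000 nM is a limit and not an exact number.

Compound 4 `COc1ccc2c(c1C)NC(=O)C2(c1ccc(O)cc1)C1CCCCCC1` is built like compound 3, but it carries methoxy in place of chloro on an aromatic carbon, ortho to a methyl group (methoxy in place of chloro on an aromatic carbon). Among the compounds with values here, no two measured compounds differ in one place only, so no measured step shows what this exchange does. The starting point is therefore compound 3 at 150 nM, and the expectation carries real uncertainty. A modest move towards weaker inhibition in this assay is expected, an estimated step of a 2.0-fold higher number from compound 3 to compound 4 (0.30 log units; within the scatter). The estimate for compound 4 is 300 nM, with an expected range of 60 nM to 1500 nM.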

Compound 4, half-maximal inhibitory concentration: 12 nM
Beside the measured number, compound 4's estimate is 25-fold (1.40 log units) above it; the measured number lies below the stated range.
By their numbers in this assay, from the lowest: compound 1; then compound 4; then compound 3. At a limit, above all of these: compound 2.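

Within the data shown here, the exchange of chloro for methoxy on this aromatic carbon, ortho to a methyl group, gives the first step here that changes one place only, and in this assay it reads a 13-fold lower number from compound 3 to compound 4 (1.10 log units; beyond the scatter) in size. This position is therefore sensitive to the group it carries, and here the group with more heavy atoms and a hydrogen-bond acceptor, which chloro does not have, gives the lower number. Nothing given here explains why the number falls.

What an amine or an ethoxy group would do on this same carbon stays open, since chloro and methoxy are the only groups shown there for comparison. Also open, as far as these compounds go, is whether the same exchange would give a step of similar size on the core of compound 1.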